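Isopropyl in place of butyl on the aromatic nitrogen

This account rests on a few compounds, and the source may have more. Where it says the series, first, only, none or still open, it means among the compounds named here.

Measured so far in an assay on isolated protein for inhibition of Gonadotropin-releasing hormone receptor (Homo sapiens); a lower number here means a stronger inhibitor, a higher number a weaker inhibitor:
compound 1 `COc1ccccc1CSc1nc2cc(NC(=O)C3CC3)ccc2n1C(C)C` gives 2100 nM;
compound 2 `CCCCn1c(SCc2cc([N+](=O)[O-])ccc2OC)nc2cc(NC(=O)NC(C)(C)C)ccc21` gives 23 nM;
compound 3 `COc1ccc([N+](=O)[O-])cc1CSc1nc2cc(NC(=O)C3CCC3)ccc2n1C(C)C` gives 1500 nM.

Compound 2 holds the lowest number of the three. Compound 3 is nearest to it and compound 1 furthest, both gaps lying beyond the scatter. Compound 4 `COc1ccc([N+](=O)[O-])cc1CSc1nc2cc(NC(=O)NC(C)(C)C)ccc2n1C(C)C` differs from compound 2 in one place: isopropyl in place of butyl on an aromatic nitrogen. Within the data shown here, no measured pair isolates this change; compounds 1 and 3 carry the isopropyl but differ from compound 2 elsewhere as well, so their numbers do not speak to it alone. The step is expected to be small, a mild loss or none beyond the scatter. Compound 4 is estimated at 40 nM, in the range 15 nM to 120 nM, which means an expected step of a 1.7-fold higher number from compound 2 to compound 4 (0.24 log units; within the scatter).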

Compound 4, half-maximal inhibitory concentration: 62 nM
Estimate against measurement, compound 4: 1.6-fold (0.19 log units) below; the measured number falls inside the stated range.
By their numbers in this assay, from the lowest: compound 2; then compound 4; then compounds 3 and 1 (each within the scatter of the next).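

In this assay, isopropyl in place of butyl on the aromatic nitrogen gives a 2.7-fold higher number from compound 2 to compound 4 (0.43 log units; beyond the scatter), so this position accepts the change with only a modest loss. With isopropyl held constant, (tert-butyl)amino in place of cyclobutyl on the carbonyl carbon gives a 24-fold lower number from compound 3 to compound 4 (1.38 log units; beyond the scatter), a much larger step than the one on the nitrogen. No evidence available here bears on either step.

From the compounds shown here alone, whether a longer chain such as hexyl keeps the number low at the aromatic nitrogen remains open. So does the effect of a chain ending in an amine there.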